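Replacing Methoxy with Pyrrolidinyl at the Ring Position

The source may report more compounds than this note shows. Statements on the series, on what has been measured and on what is new or still open speak of the compounds shown alone.

The measured compounds:
In an in vitro functional assay on HEK285-7 cells for antagonist activity at prostaglandin D2 receptor 2 (Homo sapiens), read by BRET and beta-arrestin recruitment (on this read-out lower numbers stand for stronger inhibition and higher numbers for weaker inhibition), compound 1 `O=C(O)Cc1sc(C(c2ccc(F)cc2)c2ccc(F)cc2)nc1-c1ccnc(F)c1` gives 4.7 nM.
In this assay compound 2 `COc1cc(-c2nc(C(c3ccc(F)cc3)c3ccc(F)cc3)sc2CC(=O)O)ccn1` gives 380 nM.

Among the measured compounds shown here, compound 2 holds the higher of the two numbers, and the single measured step, an 81-fold higher number from compound 1 to compound 2 (1.91 log units; beyond the scatter), is large and well beyond the scatter; it concerns a methoxy in place of fluoro on an aromatic carbon.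

Compound 3 `O=C(O)Cc1sc(C(c2ccc(F)cc2)c2ccc(F)cc2)nc1-c1ccnc(N2CCCC2)c1` differs from compound 2 by pyrrolidin-1-yl in place of methoxy on an aromatic carbon; cut one bond further out, 2-methoxypyridin-4-yl becomes 2-(pyrrolidin-1-yl)pyridin-4-yl. For the measured compounds named here, no measured pair exchanges methoxy for pyrrolidin-1-yl, so the only step that bears on this position is the one above, and it shows that a change at this carbon can move the number a great deal. Because an 81-fold higher number from compound 1 to compound 2 (1.91 log units; beyond the scatter) was unfavourable, a further modest weakening is expected in this assay , though a result within the scatter cannot be excluded. The expected step is a 1.8-fold higher number from compound 2 to compound 3 (0.27 log units; within the scatter). For compound 3 the estimated value is 700 nM, within a range from 150 nM to 3000 nM.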

Compound 3, half-maximal inhibitory concentration: > 100000 nM
Compound 3: only a limit was reported; the forecaster's own chance of this, stated with the estimate: 5%; middle value at least 140-fold (2.15 log units) away from the limit.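

Compound 2 had already lost much of the strength of compound 1, but it still gave a measured number. The exchange of methoxy for pyrrolidin-1-yl next to the ring nitrogen goes much further in this assay, with an at least 260-fold higher number from compound 2 to compound 3 (2.42 log units; beyond the scatter), so this carbon does not simply tolerate a larger group with a five-membered non-aromatic ring. The value of compound 3 is a limit of the assay and not a number: the limit of > 100000 nM in this assay, at which 1 of the 3 values shown sits. Measured against the fluoro group, the change is an at least 21000-fold higher number from compound 1 to compound 3 (4.32 log units; beyond the scatter), and the three compounds place fluoro, methoxy and pyrrolidin-1-yl in order of rising numbers, with none going against that order, although three groups on one carbon make no general rule.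

The compounds shown do not tell whether the loss belongs to the pyrrolidine ring itself or to any amine at this carbon, a question that a plain amino group or an open-chain dimethylamino group would address. They also leave open how a chloro or methyl group, or a hydrogen in place of fluoro, would compare with compound 1.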